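This account rests on a few compounds, and the source may have more. Where it says the series, first, only, none or still open, it means among the compounds named here.

Measured compounds:
- compound 1, `C#CCOc1ccc(/C=C/C(=O)c2ccc(Br)cc2)cc1`, 34%
- compound 2, `C#CCOc1ccc(/C=C/C(=O)c2ccc(OC)cc2)cc1`, 27%
- compound 3, `O=C(/C=C/c1ccc(OCc2cn(Cc3ccccc3)nn2)cc1)c1ccc(Br)cc1`, 34%

All three were tested in a functional assay on A549 cells (Homo sapiens) for inhibition, read by MTT assay, with a stated time of 48 h, tested at 10 uM; a higher number here means more inhibition of growth at the concentration tested, a lower number less inhibition of growth. Compound 1 and compound 2 share a core and differ in one place: methoxy in place of bromo on an aromatic carbon. The step of a number 7 percentage points lower from compound 1 to compound 2 (within the scatter) is small and lies inside the usual scatter, so the two values cannot be ordered against each other.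

Compound 3 carries a different core from compound 1; the difference between the two cores is not broken down here. In this assay compound 3 gives 34%, level with compound 1 at the digits printed, and compound 3 and compound 1 are together the highest of the three numbers, while compound 2 sits lower by an amount that is still within the scatter.

Compound 4, `COc1ccc(C(=O)/C=C/c2ccc(OCc3cn(Cc4ccccc4)nn3)cc2)cc1`, is not yet measured. It stands to compound 3 as compound 2 stands to compound 1: methoxy in place of bromo on an aromatic carbon. The place of the change is the same in both pairs, so this is the same change made on a second core. Within the data shown here, the only measured instance, a number 7 percentage points lower from compound 1 to compound 2 (within the scatter), was within the scatter, and compound 3 gives 34% as the starting point, so the expected step in this assay is a small one, a number 6 percentage points lower from compound 3 to compound 4 (within the scatter), resting on that single earlier step. For compound 4 the expected value in this assay is 28%, with a plausible range from 15% to 40%.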

Compound 4, percent growth inhibition at one concentration: 44%
For compound 4 the middle estimate is 16 percentage points below the measured one, outside the stated range (above it).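

In this assay, methoxy in place of bromo on an aromatic carbon gives the step of a number 10 percentage points higher from compound 3 to compound 4 (within the scatter) on the second core, and taken alone this step does not order the two compounds. Among these compounds, the change therefore cannot be treated as a single fixed step, although each core supplies only one pair, read at one concentration on one cell line, so the data do not show which feature of the cores accounts for the gap or how the change would behave on any further core. Set beside the earlier step, the outcome of the swap differs between the core of compound 1 and the core of compound 3: the same change on two cores in this assay, a number 7 percentage points lower (within the scatter) from compound 1 to compound 2 and a number 10 percentage points higher (within the scatter) from compound 3 to compound 4, 17 percentage points apart, beyond the scatter of two such steps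

The compounds shown carry only bromo or methoxy at this place, so it remains open whether an amine, a carboxylic acid or a nitrile on the same aromatic carbon would follow the step seen on either core. Also open, going by these compounds, is which part of the difference between the two cores goes with the gap between the steps, and whether the same gap would appear at other concentrations or on other cell lines.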